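The compounds below may be only part of what the source reports. "The series", "measured", "known", "first", "only" and "open" are said of these compounds alone.

Measured compounds:
compound 1 `C/C(=C\C(=O)Nc1ccccc1OCCCC(=O)O)c1ccc2c(ccn2C)c1`: 780 nM
compound 2 `CCCCCn1ccc2cc(/C(C)=C/C(=O)Nc3ccccc3OCCCC(=O)O)ccc21`: 23 nM

Among the measured compounds shown here, in an assay on Prostate gland for inhibition of steroid 5-alpha-reductase (Rattus norvegicus) (a higher number here means a weaker inhibitor, a lower number a stronger inhibitor), compound 2 stands at the lower of the two numbers recorded; compound 1 gives 780 nM, and the only step measured so far is a 34-fold lower number from compound 1 to compound 2 (1.53 log units; beyond the scatter), a large change at the chain on the aromatic nitrogen. Compound 3 `C/C(=C\C(=O)Nc1ccccc1OCCCC(=O)O)c1ccc2c(ccn2CC(C)C)c1` is not yet measured in this assay. It differs from compound 2 by isopropyl in place of butyl on a saturated chain carbon bound to an aromatic nitrogen. For the measured compounds named here, the one step that bears on this place shows that shortening the chain on the aromatic nitrogen from pentyl to methyl raises the number strongly; isobutyl sits between those two in length, so compound 3 is expected to fall between compound 1 and compound 2, closer to compound 2. Compound 3 is therefore estimated at 80 nM, with a range of 25 nM to 250 nM, corresponding to an expected step of a 3.5-fold higher number from compound 2 to compound 3 (0.54 log units; beyond the scatter).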

Compound 3, half-maximal inhibitory concentration: 160 nM
Compound 3: middle estimate off by 2.0-fold (0.30 log units), on the low side; low and high end bracket the measured number.
By their numbers in this assay, from the lowest: compound 2; then compound 3; then compound 1.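

In this assay, the chain on the aromatic nitrogen now gives a graded response rather than a simple contrast between methyl and pentyl: a 4.9-fold lower number from compound 1 to compound 3 (0.69 log units; beyond the scatter), so isobutyl keeps part of the gain over methyl, while a 7.0-fold higher number from compound 2 to compound 3 (0.84 log units; beyond the scatter), so it does not match pentyl. Both steps lie beyond the scatter, which places isobutyl apart from each of the other two chains. No data shown offer an explanation for this order.

The change from pentyl to isobutyl alters chain length and branching together, so the compounds shown do not separate the two. A straight butyl chain would bear on that question, while hexyl or benzyl would show whether the number keeps falling past pentyl or with a ring at this place.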